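A few compounds are considered here, and "the series" means these few. Any claim that something is new, unique, unknown or untested is made for them only; others in the source may bear on it.

Compound 1 `Cc1ccc(Nc2ncc3c(n2)N(C)C(=O)N(c2cc(NC(=O)c4cccc(C(F)(F)F)c4)ccc2C)C3)cc1N(C)C`: in a functional assay on K562 cells (Homo sapiens) for antiproliferative activity, read by CellTiter-Glo and CCK-8 assay, with a stated time of 72 h (on this read-out higher numbers stand for weaker inhibition of growth and lower numbers for stronger inhibition of growth), compound 1 gives 28 nM.
Compound 2 `Cc1cccc(C(=O)Nc2ccc(C)c(N3Cc4cnc(Nc5ccc(C)c(N)c5)nc4N(C)C3=O)c2)c1`: in this assay compound 2 gives 68.8 nM.
Compound 3 `CNc1nc(Nc2ccc(C)c([N+](=O)[O-])c2)ncc1C(=O)Nc1cc(NC(=O)c2ccccc2OC)ccc1C`: in this assay compound 3 gives only a limit, > 10000 nM.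

Going by the values given here, compound 3 thus stands apart from the other two: it is the one value that sits at the limit of > 10000 nM in this assay, at which 1 of the 3 values shown sits, and no number for its growth inhibition is known. Compound 4 `CNc1nc(Nc2ccc(C)c([N+](=O)[O-])c2)ncc1C(=O)Nc1cc(NC(=O)c2ccc(OC)c(OC)c2)ccc1C` differs from compound 3 by 3,4-dimethoxyphenyl in place of 2-methoxyphenyl on a carbonyl carbon. Among the compounds with values here, no measured pair shows the effect of such a change, and compound 3 gives no number from which to move. The expected step in this assay is a step that the limit leaves unreadable from compound 3 to compound 4, none beyond the scatter. Compound 4 is accordingly expected at 15000 nM in this assay, with a range from 3000 nM to 60000 nM, and it may well again return only a limit.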

Compound 4, concentration for 50% growth inhibition: 680 nM
Compound 4: the middle estimate sits 22-fold (1.34 log units) above what was measured, outside the stated range (below it).
By their numbers in this assay, from the lowest: compound 1; then compound 2; then compound 4. At a limit, above all of these: compound 3.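

In this assay, the group on this carbonyl carbon clearly matters: 3,4-dimethoxyphenyl in place of 2-methoxyphenyl brings an at least 14-fold lower number from compound 3 to compound 4 (1.16 log units; beyond the scatter). Going by these compounds alone, this is the first measured change at this place, and compound 4 gives 680 nM. The full size of the step remains unknown, as its starting point is a limit: the limit of > 10000 nM in this assay, at which 1 of the 4 values shown sits.

The compounds shown leave open whether both methoxy groups of 3,4-dimethoxyphenyl are needed for this step. They also leave open how an amine or a carboxylic acid on that phenyl ring would read.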